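Adding a second methyl to the aryl ring of compound 3

The compounds below may be only part of what the source reports. "The series", "measured", "known", "first", "only" and "open" are said of these compounds alone.

Three compounds share one core and were tested in a functional assay on NCI-H460 cells (Homo sapiens) for cytotoxicity, read by MTT assay, with a stated time of 72 h; a higher number here means a weaker inhibitor, a lower number a stronger inhibitor. Compound 1 `COc1cc2c(Oc3ccc(NC(=O)c4cn(-c5c(C)cccc5C)nn4)cc3F)ccnc2cc1OCCCN1CCCC1` gives 1560 nM. Compound 2 `COc1cc2c(Oc3ccc(NC(=O)c4cn(-c5c(C)cccc5C)nn4)cc3F)ccnc2cc1OCCCN1CCC(C)CC1` gives 2360 nM. Compound 3 `COc1cc2c(Oc3ccc(NC(=O)c4cn(-c5ccccc5C)nn4)cc3F)ccnc2cc1OCCCN1CCN(C)CC1` gives 3650 nM. For the measured compounds named here, the one direct comparison among them, a 1.5-fold higher number from compound 1 to compound 2 (0.18 log units; within the scatter), shows that swapping the amine at the end of the chain changes little. Compound 3 sits within the scatter of compound 2, while its gap to compound 1 lies beyond the scatter; compound 3 differs from both in two places at once, so neither gap can be assigned to a single change.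

Compound 4 `COc1cc2c(Oc3ccc(NC(=O)c4cn(-c5c(C)cccc5C)nn4)cc3F)ccnc2cc1OCCCN1CCN(C)CC1` is compound 3 with methyl in place of hydrogen on an aromatic carbon, placed ortho to a large group and meta to a methyl group on the six-membered ring of carbon only. Going by the values given here, no measured step isolates this change: compounds 1 and 2 carry the 2,6-dimethylphenyl but also a different amine. Since both of them give lower numbers than compound 3, a modest step downward, a 1.8-fold lower number from compound 3 to compound 4 (0.26 log units; within the scatter), is expected, though it may stay within the scatter. In this assay compound 4 is therefore estimated at 2000 nM, with a plausible range from 900 nM to 4500 nM.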

Compound 4, half-maximal inhibitory concentration: 4540 nM
The estimate for compound 4 lay 2.3-fold (0.36 log units) below the measured number; the whole stated range lies below it.
By their numbers in this assay, from the lowest: compounds 1, 2, 3 and 4 (each within the scatter of the next, the first and the last beyond it).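

Read on its own for the first time, the change from 2-methylphenyl to 2,6-dimethylphenyl in this assay is a 1.2-fold higher number from compound 3 to compound 4 (0.09 log units; within the scatter) and so gives no shift that can be told apart from repeat-measurement scatter, at least with 4-methylpiperazin-1-yl at the end of the chain. For the compounds shown here, compound 4 also opens the amine to direct comparison with the aryl ring held constant: 4-methylpiperazin-1-yl in place of 4-methylpiperidin-1-yl is a 1.9-fold higher number from compound 2 to compound 4 (0.28 log units; within the scatter) and stays within the scatter, whereas 4-methylpiperazin-1-yl in place of pyrrolidin-1-yl is a 2.9-fold higher number from compound 1 to compound 4 (0.46 log units; beyond the scatter) and is the one modest step here that clears it. Nothing at hand explains why these numbers fall where they do.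

From the compounds shown here alone, the second methyl is read against only one amine, so it remains open whether the same step would hold with pyrrolidin-1-yl at the end of the chain. Also open, going by these compounds, is what a chlorine or a methoxy group at this aromatic carbon, or a morpholine at the end of the chain, would do to the number.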